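A Fluoro for a Methoxy at Melanocortin Receptor 4

A few compounds are considered here, and "the series" means these few. Any claim that something is new, unique, unknown or untested is made for them only; others in the source may bear on it.

Of the compounds shown here, three built on one shared core have been measured in a functional assay on CHO cells for agonist activity at Melanocortin receptor 4 (Homo sapiens), read by a luciferase reporter, with a stated time of 4 h; on this read-out lower numbers stand for an effect already at smaller amounts and higher numbers for an effect only at larger amounts of compound. Compound 1 `CC(C)N(C(=O)CN1C=CN(c2ccccc2)C(=O)C(Cc2n[nH]c3ccccc23)C1=O)c1ccc(F)cc1` gives 282 nM. Compound 3 `COc1ccc(N(C(=O)CN2C=CN(c3ccccc3)C(=O)C(Cc3n[nH]c4cc(F)ccc34)C2=O)C(C)C)cc1` gives 355 nM, the higher of the two numbers recorded, though its gap to compound 1 lies within the scatter of this assay, so the two cannot be told apart. Compound 2 `CC(C)N(C(=O)CN1C=CN(C)C(=O)C(Cc2n[nH]c3cc(F)ccc23)C1=O)c1ccc(F)cc1` gives 31600 nM; > 30000 nM (2 entries), as the entries recorded for it in this assay show (the several entries of compound 2 in this assay, 31600 nM; > 30000 nM (2 entries)).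

Compound 4 `CC(C)N(C(=O)CN1C=CN(c2ccccc2)C(=O)C(Cc2n[nH]c3cc(F)ccc23)C1=O)c1ccc(F)cc1` is the next structure. It differs from compound 3 in a single place: fluoro in place of methoxy on an aromatic carbon, a fluoro in place of methoxy on an aromatic carbon. Among the measured compounds shown here, no measured pair here shares exactly this change, so its size is not known from the data. Compound 1, which carries the same fluorophenyl group as compound 4, sits within the scatter of compound 3, so no step beyond the scatter is expected from compound 3 to compound 4 in this assay, that is a 1.2-fold lower number from compound 3 to compound 4 (0.07 log units; within the scatter). Compound 4 is therefore estimated to give about 300 nM, with a likely range from 120 nM to 750 nM.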

Compound 4, half-maximal effective concentration: 178 nM
For compound 4 the middle estimate is 1.7-fold (0.23 log units) above the measured one; measured number inside the range.
By their numbers in this assay, from the lowest: compounds 4, 1 and 3 (each within the scatter of the next).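

In this assay, among the compounds shown here, replacing the 4-methoxyphenyl with a 4-fluorophenyl gives a 2.0-fold lower number from compound 3 to compound 4 (0.30 log units; within the scatter) and so shows that a methoxy and a fluoro at this aromatic carbon cannot be told apart in this assay, a point the earlier compounds could not address. A fluoro in place of hydrogen on an aromatic carbon gives a 1.6-fold lower number from compound 1 to compound 4 (0.20 log units; within the scatter) and likewise leaves no difference that can be read. Nothing measured among these compounds offers a reason for these numbers.

Among the compounds shown, this carbon carries only a methoxy or a fluoro, so it remains open how an amine, a carboxylic acid or a longer chain such as butoxy would read there. Also open, on these data alone, is whether a plain hydrogen at this carbon would fit the same picture.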